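Halogen swap on an aryl triazene series, Vero cytotoxicity

The source may report more compounds than this note shows. Statements on the series, on what has been measured and on what is new or still open speak of the compounds shown alone.

Measured so far:
compound 1, `Clc1cccc(/N=N/N2CCCCC2)c1`, > 100000 nM
compound 2, `Brc1cccc(/N=N/N2CCCCC2)c1`, 85000 nM
compound 3, `Clc1ccc(/N=N/N2CCCC2)cc1`, > 100000 nM

In an ADME assay on Vero cells (Chlorocebus sabaeus) for cytotoxicity, read by crystal violet staining (on this read-out lower numbers stand for higher toxicity in this test and higher numbers for lower toxicity in this test), compound 1 gives only a limit, > 100000 nM. Compound 3 likewise gives only a limit in this assay, > 100000 nM. Within the data shown here, compound 2 is the one compound with a number, 85000 nM in this assay.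

The measured step, an at least 1.1-fold lower number from compound 1 to compound 2 (0.07 log units; that floor lies within the scatter), is the change (bromo in place of chloro on an aromatic carbon). Its size is only a floor, because the limit of > 100000 nM in this assay, at which 2 of the 3 values shown sit, leaves the starting point open. The difference between the core of compound 1 and the core of compound 3 is not broken down here.

Compound 4, `Brc1ccc(/N=N/N2CCCC2)cc1`, is not yet measured in this assay. It differs from compound 3 by bromo in place of chloro on an aromatic carbon, the same kind of change as that from compound 1 to compound 2, but the surroundings differ: in the measured pair the place is meta to a group of 8 heavy atoms, in the new pair it is para to a group of 7 heavy atoms.

The step from compound 3 to compound 4 is expected to be small, an at least 1.1-fold lower number from compound 3 to compound 4 (0.04 log units; that floor lies within the scatter), resting on the measured floor an at least 1.1-fold lower number from compound 1 to compound 2 (0.07 log units; that floor lies within the scatter) and on compound 3 sitting at > 100000 nM. Compound 4 is expected to give about 90000 nM, estimated within 45000 nM to 150000 nM, and may well return only a limit again.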

Compound 4, half-maximal cytotoxic concentration: >= 100000 nM
Compound 4: no number, only a limit; the forecaster's own chance of this, stated with the estimate: 55%; middle value at least 1.1-fold (0.04 log units) from the limit.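

No step can be read from compound 3 to compound 4 in this assay, since both compounds return only a limit and neither gives a number. The compounds shown leave open how large the change of bromo in place of chloro on an aromatic carbon is in this pair, and whether it matches the change seen between compound 1 and compound 2.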